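A few compounds are considered here, and "the series" means these few. Any claim that something is new, unique, unknown or untested is made for them only; others in the source may bear on it.

Compound 1 `COc1cccc(CNc2ncnc3ncc(-c4cnn(C)c4)cc23)c1` and compound 2 `Cn1cc(-c2ccc3ncnc(Nc4ccc5ncccc5c4)c3c2)cn1` share one core and differ in the amine attached to it. In a functional assay on SK-BR-3 cells (Homo sapiens) for antiproliferative activity, read by MTT assay, with a stated time of 72 h (a lower number here means a stronger inhibitor, a higher number a weaker inhibitor), compound 1 gives only a limit, > 100000 nM. On the numbers shown, compound 1 therefore stands at the limit of > 100000 nM in this assay, at which 1 of the 2 values shown sits, with no measured number of its own. In this assay compound 2 gives 64 nM. Compound 3 `Cn1cc(-c2cnc3ncnc(NCc4cccc([N+](=O)[O-])c4)c3c2)cn1` is not yet measured in this assay. It differs from compound 1 in one place: nitro in place of methoxy on an aromatic carbon. For the measured compounds named here, no step between two measured compounds follows this change, so its size in this assay can only be expected, not read off. Because compound 1 sits at the limit of > 100000 nM in this assay, at which 1 of the 2 values shown sits, there is no number from which a move could be counted, and the two values shown give no ground to expect the change to nitro in place of methoxy to carry the step beyond the scatter. Compound 3 is therefore expected to give about 70000 nM, estimated between 15000 nM and 300000 nM, with a fair chance that this assay again reports only a limit. The step expected in this assay is an at least 1.4-fold lower number from compound 1 to compound 3 (0.15 log units; that floor lies within the scatter).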

Compound 3, half-maximal inhibitory concentration: > 100000 nM
Compound 3: no number, only a limit; the forecaster's own chance of this, stated with the estimate: 60%; middle value at least 1.4-fold (0.15 log units) from the limit.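

Compound 1 and compound 3 both give only a limit in this assay, so no step between them can be read: the limit of > 100000 nM in this assay, at which 2 of the 3 values shown sit.

The compounds shown leave open whether nitro in place of methoxy moves the activity of the shared core at all.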